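A few compounds are considered here, and "the series" means these few. Any claim that something is new, unique, unknown or untested is made for them only; others in the source may bear on it.

In a functional assay on RD cells (Homo sapiens) for inhibition, read by luminescence and ATP content, with a stated time of 72 h (on this read-out lower numbers stand for higher toxicity in this test and higher numbers for lower toxicity in this test), compound 1 (`CCCCc1ccc(-c2ccc3ncc(-c4noc(CC)n4)cc3c2)cc1`) gives > 7400 nM as a limit of the assay. Compound 2 (`CCc1nc(-c2cnc3ccc(-c4ccc(C)cc4)cc3c2)no1`) gives > 7400 nM as a limit too. It therefore stands without a number, and the record holds only the limit of > 7400 nM in this assay, at which 2 of the 2 values shown sit, as its evidence. Compound 3 (`CCc1nc(-c2cnc3ccc(-c4ccc(O)cc4)cc3c2)no1`) carries hydroxy in place of methyl on an aromatic carbon, and the difference reads hydroxy in place of methyl on an aromatic carbon against compound 2. Among the measured compounds shown here, the only measured step, a step that the two limits leave unreadable from compound 1 to compound 2 as it stands, gives no size, so no step beyond the scatter is expected in this assay and no direction is favoured. The estimate implies a number no higher from compound 2 to compound 3 (the limit leaves the size open) as the expected change. Compound 3 is estimated at 7400 nM with 3000 nM to 12000 nM as its expected range.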

Compound 3, half-maximal cytotoxic concentration: > 2500 nM
Compound 3: no number, only a limit; the forecaster's own chance of this, stated with the estimate: 75%; the middle value lies beyond the limit too.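

Among the compounds shown here, compound 1, compound 2 and compound 3 stand only as limits in this assay, so no step among them can be read. On these data alone, whether hydroxy in place of methyl changes the half-maximal cytotoxic concentration at all, and by how much, stays open.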